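Aryl replacement on the ring nitrogen: compound 3 to compound 4

This account rests on a few compounds, and the source may have more. Where it says the series, first, only, none or still open, it means among the compounds named here.

Compound 3 `CCc1cccc(C)c1-n1nncc1CN1C(=O)C2(C(C#N)=C(N)Oc3c(N)cc4nc5ccccc5nc4c32)c2ccccc21` is read in a functional assay on HepG2 cells (Homo sapiens) for antiproliferative activity, read by MTT assay, with a stated time of 48 h (on this read-out higher numbers stand for weaker inhibition and lower numbers for stronger inhibition), only as a limit, > 50000 nM. Compound 1 `COc1ccccc1-n1nncc1CN1C(=O)C2(C(C#N)=C(N)Oc3c(N)cc4nc5ccccc5nc4c32)c2ccccc21` likewise reaches only a limit, > 50000 nM. Compound 2 `CCOc1ccccc1-n1nncc1CN1C(=O)C2(C(C#N)=C(N)Oc3c(N)cc4nc5ccccc5nc4c32)c2ccccc21` gives a number, 30500 nM. Compound 3 thus stands at the limit of > 50000 nM in this assay, at which 2 of the 3 values shown sit, not at a number. Compound 4 `N#CC1=C(N)Oc2c(N)cc3nc4ccccc4nc3c2C12C(=O)N(Cc1cnnn1-c1ccc(Cl)cc1[N+](=O)[O-])c1ccccc12` differs from compound 3 by 4-chloro-2-nitrophenyl in place of 2-ethyl-6-methylphenyl on an aromatic nitrogen. The measured steps on the same aromatic nitrogen are a step that the two limits leave unreadable from compound 1 to compound 3 and an at least 1.6-fold higher number from compound 2 to compound 3 (0.21 log units; that floor lies within the scatter); the first is unreadable, the second lies within the scatter. Neither gives a readable direction for exchanging the aryl group, so no step beyond the scatter is expected, and a step of an at least 1.1-fold lower number from compound 3 to compound 4 (0.04 log units; that floor lies within the scatter) is estimated. Compound 4 is therefore expected near 45000 nM, between 15000 nM and 150000 nM, most likely reported again only as a limit.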

Compound 4, half-maximal inhibitory concentration: > 50000 nM
Compound 4 gave a limit, no number (the forecaster's own chance of this, stated with the estimate: 60%); middle value at least 1.1-fold (0.04 log units) from the limit.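

Compound 4 shows that 4-chloro-2-nitrophenyl, with its nitro group and chlorine, also leaves this aromatic nitrogen at a limit in this assay, as do the 2-methoxyphenyl of compound 1 and the 2-ethyl-6-methylphenyl of compound 3, with compound 2 the only exception: the limit of > 50000 nM in this assay, at which 3 of the 4 values shown sit. Among these compounds, the one readable comparison is an at least 1.6-fold higher number from compound 2 to compound 4 (0.21 log units; that floor lies within the scatter), so even this change of aryl group gives no step beyond the scatter. The steps to compound 4 from compound 1 and from compound 3 cannot be read.

Going by these compounds, whether any aryl group here can give a clear gain stays open. A 2-propoxyphenyl group or an aminophenyl group would test this.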